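Replacing the Acid with a Dimethylamide

The source may hold more compounds than are shown below. What is called first, only, known or untested is meant among the compounds shown, and "the series" means these compounds.

Of the compounds shown here, three built on one shared core have been tested in a functional assay on MDA-MB-231 cells (Homo sapiens) for inhibition, read by sulforhodamine B assay, with a stated time of 72 h; a lower number here means a stronger inhibitor of growth, a higher number a weaker inhibitor of growth. Compound 1 `COC1CN(C(=O)/C=C/c2ccncc2-c2ccc3ccccc3c2)C1` is an amide formed with 3-methoxyazetidin-1-yl, compound 2 `COC(=O)/C=C/c1ccncc1-c1ccc2ccccc2c1` is the methyl ester, and compound 3 `O=C(O)/C=C/c1ccncc1-c1ccc2ccccc2c1` is the free acid. For compound 1 the assay reports only a limit, > 10000 nM. Compound 2 gives a real number, 4710 nM. For compound 3 the result is again only a limit, > 10000 nM. Compound 3 therefore stands at the edge of what the assay can report, a position it shares with one other value (the limit of > 10000 nM in this assay, at which 2 of the 3 values shown sit). The readable steps are an at least 2.1-fold lower number from compound 1 to compound 2 (0.32 log units; beyond the scatter) and an at least 2.1-fold higher number from compound 2 to compound 3 (0.32 log units; beyond the scatter), while a step that the two limits leave unreadable from compound 1 to compound 3.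

Among the measured compounds shown here, compound 4 `CN(C)C(=O)/C=C/c1ccncc1-c1ccc2ccccc2c1` is the next compound. dimethylamino in place of hydroxy on a carbonyl carbon The change turns the acid into a tertiary amide, which makes compound 1 the nearest precedent, since it is also an amide on that carbonyl carbon and sits at the limit, > 10000 nM. Because of an at least 2.1-fold lower number from compound 1 to compound 2 (0.32 log units; beyond the scatter), an amide is expected to be no stronger than the ester. For compound 4 in this assay the estimated value is 9000 nM, within 3000 nM to 30000 nM. The expected step is therefore an at least 1.1-fold lower number from compound 3 to compound 4 (0.04 log units; that floor lies within the scatter), most likely not beyond the scatter.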

Compound 4, concentration for 50% growth inhibition: 7990 nM
The estimate for compound 4 lay 1.1-fold (0.05 log units) above the measured number; low and high end bracket the measured number.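

Among the compounds shown here, compound 4 is the first amide on this carbonyl carbon to give a real number in this assay and so shows that an amide here need not sit at the limit of the assay. The step is a 1.7-fold higher number from compound 2 to compound 4 (0.23 log units; within the scatter) and so dimethylamino and methoxy cannot be told apart on this carbonyl carbon by this read-out. The remaining two steps are an at least 1.2-fold lower number from compound 3 to compound 4 (0.09 log units; that floor lies within the scatter) and an at least 1.2-fold lower number from compound 1 to compound 4 (0.09 log units; that floor lies within the scatter) and give only floors, so their true size cannot be read, because each starts from a compound that has a limit instead of a number: the limit of > 10000 nM in this assay, at which 2 of the 4 values shown sit.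

The compounds shown leave open how other groups on the same carbonyl carbon would behave, such as a methylamino group, an ethoxy group or a piperidin-1-yl group. They also leave open whether any group in this place can bring the number clearly below that of compound 2, or whether changes elsewhere on the shared core would be needed for that.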